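One Stereocentre Redrawn, Tolerance Expected to Hold

The source may report more compounds than this note shows. Statements on the series, on what has been measured and on what is new or still open speak of the compounds shown alone.

Among the compounds with values here, in a functional assay on Vero cells (Chlorocebus sabaeus) for cytotoxicity (a higher number here means that more compound is tolerated, a lower number that less compound is tolerated), compound 1 `O=c1[nH]c(=O)n([C@@H]2CO[C@H](CO)O2)cc1/C=C/Br` gives 100 ug/mL and compound 2 `O=c1[nH]c(=O)n([C@H]2CO[C@@H](CO)O2)cc1/C=C/Br` gives 100 ug/mL, so compound 2 stands level with its only measured neighbour. Compound 3 `O=c1[nH]c(=O)n([C@@H]2CO[C@@H](CO)O2)cc1/C=C/Br` has the same atoms and bonds as compound 2: the two compounds have the same atoms and bonds and differ only in configuration as drawn: 1 of 3 stereo elements differ; a stereocentre at a saturated ring carbon is drawn R in compound 2 and S in compound 3. In other words, one stereocentre at a saturated ring carbon is drawn R in compound 2 and S in compound 3. Within the data shown here, the one measured step that bears on this, no change at the digits printed from compound 1 to compound 2 (within the scatter), was also purely a change of configuration (the fact that compounds 1 and 2 differ only in the configuration as drawn), and it stayed within the scatter although two stereocentres differ. A single step is thin evidence, but it gives no reason to expect a real shift in this assay. The expected step is no change at the digits printed from compound 2 to compound 3 (within the scatter), with none beyond the scatter and no favoured direction. For compound 3 the estimated value is 100 ug/mL, with an expected range of 50 ug/mL to 200 ug/mL.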

Compound 3, half-maximal cytotoxic concentration: 100 ug/mL
For compound 3 middle estimate and measured number coincide at the digits printed; low and high end bracket the measured number.
By their numbers in this assay, from the lowest: compounds 1, 2 and 3 (each within the scatter of the next).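

Compounds 1 and 2 differ at two stereocentres at once, so they could not show what happens when only one is redrawn. In this assay, compound 3 separates the two saturated ring carbons: redrawing one gives no change at the digits printed from compound 2 to compound 3 (within the scatter), and redrawing the other gives no change at the digits printed from compound 1 to compound 3 (within the scatter). Neither centre alone, nor both together, moves the tolerated concentration beyond the scatter, and the comparison is clean, as nothing else varies: the fact that compounds 2 and 3 differ only in the configuration as drawn

All three compounds carry the same groups, so these results speak only to configuration. As far as these compounds go, it remains open whether tolerance would hold if an amine or a carboxylic acid stood in place of the hydroxymethyl group, or if a longer chain replaced the bromovinyl group.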